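A few compounds are considered here, and "the series" means these few. Any claim that something is new, unique, unknown or untested is made for them only; others in the source may bear on it.

Compound 3 `c1cnc2c(c1)CCC[C@@H]2N(CCCN1CCNCC1)Cc1nc2ccccc2[nH]1` gives 63% in an ADME assay on microsomes from liver (Homo sapiens) for metabolic stability, read by LC-MS, with a stated time of 10 min, tested at 0.5 uM (a higher number here means that more of the compound is left, a lower number that less of the compound is left), the second highest of the three numbers; compound 1 `c1cnc(CN(CCCN2CCNCC2)[C@H]2CCCc3cccnc32)nc1` gives 100%, compound 2 `c1cnc2c(c1)CCC[C@@H]2N(CCCN1CCNCC1)Cc1nc2ccccc2s1` gives 50%. The measured steps were a number 37 percentage points lower from compound 1 to compound 3 (beyond the scatter), a number 50 percentage points lower from compound 1 to compound 2 (beyond the scatter) and a number 13 percentage points higher from compound 2 to compound 3 (beyond the scatter). Compound 4 `c1cnc2c(c1)CN[C@H](CN(CCCN1CCNCC1)[C@H]1CCCc3cccnc31)C2` differs from compound 3 as follows: a group of 10 heavy atoms (8 carbon, 2 nitrogen; one six-membered non-aromatic ring with 1 hetero atom, one six-membered aromatic ring with 1 hetero atom) in place of a group of 9 heavy atoms (7 carbon, 2 nitrogen; one five-membered aromatic ring with 2 hetero atoms, one six-membered aromatic ring of carbon only), on a saturated chain carbon bound to an amine nitrogen. Going by the values given here, no measured step covers this exact exchange. The six-membered aromatic ring with one hetero atom that enters is nearer to the pyrimidin-2-yl of compound 1 than to the fused rings of compounds 2 and 3, and the step of a number 37 percentage points lower from compound 1 to compound 3 (beyond the scatter) reversed would suggest a rise, tempered by the non-aromatic ring. An increase is therefore expected, a number 17 percentage points higher from compound 3 to compound 4 (beyond the scatter), and compound 4 is estimated at 80%, range 55% to 100%.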

Compound 4, percent of the compound remaining: 100%
For compound 4 the middle estimate is 20 percentage points below the measured one, and the stated range covers the measured number.
By their numbers in this assay, from the lowest: compound 2; then compound 3; then compounds 1 and 4 (each within the scatter of the next).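

In this assay, the group of 10 heavy atoms on a saturated chain carbon bound to an amine nitrogen gives a number 37 percentage points higher from compound 3 to compound 4 (beyond the scatter) and a number 50 percentage points higher from compound 2 to compound 4 (beyond the scatter), so a two-ring group at this place need not lower the number. Against pyrimidin-2-yl, it gives no change at the digits printed from compound 1 to compound 4 (within the scatter), so the extra heavy atoms carry no visible cost here. No evidence bears on what lies behind these steps. Still open, going by these compounds, is which of the two rings in the entering group accounts for the steps, and whether a pyridin-2-yl or a plain piperidine at this place would behave alike.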